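Swapping a tert-butyl for an ester on the aryl ring

The source may hold more compounds than are shown below. What is called first, only, known or untested is meant among the compounds shown, and "the series" means these compounds.

Measured so far, in a functional assay on MCF7 cells (Homo sapiens) for antiproliferative activity, read by sulforhodamine B assay, with a stated time of 48 h; a lower number here means a stronger inhibitor of growth, a higher number a weaker inhibitor of growth:
Compound 1, `NS(=O)(=O)NCCC1CCN(c2cc(-c3ccccc3)ncn2)CC1`, gives 53200 nM.
Compound 2, `Cc1ccc(-c2cc(N3CCC(CCNS(N)(=O)=O)CC3)ncn2)cc1`, gives 47500 nM.
Compound 3, `CC(C)(C)c1ccc(-c2cc(N3CCC(CCNS(N)(=O)=O)CC3)ncn2)cc1`, gives 13100 nM.

The three compounds share one core and differ only in the group on the outer aromatic carbon ring. Compound 3, carrying a tert-butyl there, has the lowest number of the three, with compound 2 nearest at a 3.6-fold lower number from compound 2 to compound 3 (0.56 log units; beyond the scatter) and compound 1 furthest at a 4.1-fold lower number from compound 1 to compound 3 (0.61 log units; beyond the scatter). Between compounds 1 and 2 the step is a 1.1-fold lower number from compound 1 to compound 2 (0.05 log units; within the scatter), so hydrogen and methyl at that place cannot be told apart here.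

Compound 4, `CCOC(=O)c1ccc(-c2cc(N3CCC(CCNS(N)(=O)=O)CC3)ncn2)cc1`, carries ethoxycarbonyl in place of tert-butyl on an aromatic carbon. For the measured compounds named here, the measured steps all concern simple carbon groups growing at this position, and the only one that moved the number beyond the scatter was the step to tert-butyl. Going by the values given here, no measured step replaces a carbon group with an oxygen-bearing one, so the steps above bear on the change only loosely. The estimate for the step from compound 3 to compound 4 is therefore a 2.3-fold higher number from compound 3 to compound 4 (0.36 log units; beyond the scatter), a weaker inhibitor than compound 3 but not necessarily back at the level of compound 1. In this assay compound 4 is expected to give about 30000 nM, in the range 8000 nM to 100000 nM.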

Compound 4, concentration for 50% growth inhibition: 6200 nM
For compound 4 the middle estimate is 4.8-fold (0.68 log units) above the measured one; the whole stated range lies above it.
By their numbers in this assay, from the lowest: compound 4; then compound 3; then compounds 2 and 1 (each within the scatter of the next).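

In this assay, the ethoxycarbonyl group gives a 2.1-fold lower number from compound 3 to compound 4 (0.32 log units; beyond the scatter), so the lowest number no longer belongs to a simple carbon group, and a group with oxygen atoms and hydrogen-bond acceptors is not only accepted at this place but goes beyond tert-butyl. For the compounds shown here, the full reach of this one place on the outer ring is also wider than the earlier compounds showed, with a 7.7-fold lower number from compound 2 to compound 4 (0.88 log units; beyond the scatter) and an 8.6-fold lower number from compound 1 to compound 4 (0.93 log units; beyond the scatter), each larger than any step among the three carbon-only cases. No measurement shown here says what lies behind this gain.

The compounds shown leave open which part of the ethoxycarbonyl group matters, the carbonyl or the ethyl end, and a methoxycarbonyl group, a carboxylic acid or a primary amide at the same place would begin to separate these parts. Going by these compounds, it also remains open whether the trend continues with a longer ester chain, or whether an amine or a simple ether at this place would give a similar number.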